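Fluoro for Hydrogen on a Core Without Measurable Cytotoxicity

The source may report more compounds than this note shows. Statements on the series, on what has been measured and on what is new or still open speak of the compounds shown alone.

Compound 1 `COc1ccc2c(=O)c(-c3ccc(Oc4ccc(OC(F)(F)F)cc4)cc3)c(C)[nH]c2c1` was tested in an ADME assay on HepG2 cells (Homo sapiens) for cytotoxicity, read by resazurin assay, with a stated time of 24 h; on this read-out higher numbers stand for weaker inhibition and lower numbers for stronger inhibition. In this assay compound 1 gives > 10000 nM, which is a limit of the assay rather than a measured number. Compound 2 `Cc1[nH]c2ccc(F)cc2c(=O)c1-c1ccc(Oc2ccc(OC(F)(F)F)cc2)nc1` gives > 10000 nM in this assay, also a limit. Compound 3 `COc1cc2[nH]c(C)c(-c3ccc(Oc4ccc(Cl)cc4)cc3)c(=O)c2cc1Cl` gives > 10000 nM in this assay, again a limit. The three share one standing: the limit of > 10000 nM in this assay, at which 3 of the 3 values shown sit. Compound 4 `COc1cc2[nH]c(C)c(-c3ccc(Oc4ccc(OC(F)(F)F)cc4)cc3)c(=O)c2cc1F` has not yet been tested; it differs from compound 1 by fluoro in place of hydrogen on an aromatic carbon. Going by the values given here, with every value sitting at a limit, no step between measured compounds can be traced, and the change is confined to that single exchange. The step from compound 1 to compound 4 is expected to be a step that the limit leaves unreadable from compound 1 to compound 4, nothing beyond the usual scatter. Compound 4 is therefore estimated at 20000 nM, within 8000 nM to 50000 nM, most likely reported again only as a limit.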

Compound 4, half-maximal inhibitory concentration: > 10000 nM
Compound 4: only a limit was reported (the forecaster's own chance of this, stated with the estimate: 85%); the middle value is on the limit's open side.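

Going by these compounds alone, compound 1 and compound 4 both stand only as limits in this assay, and no step between them can be read. The compounds shown leave open where any true value lies, and whether fluoro in place of hydrogen shifts it.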